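The source may hold more compounds than are shown below. What is called first, only, known or untested is meant among the compounds shown, and "the series" means these compounds.

Compound 1, `O=C(O)c1ccccc1-c1ccc(CCc2ncc(C3CCCCC3)[nH]2)cc1`, gives 14.7 nM in an in vitro functional assay on cells for agonist activity at Bombesin receptor subtype-3 (Mus musculus), read by luminescence and calcium flux; on this read-out lower numbers stand for an effect already at smaller amounts and higher numbers for an effect only at larger amounts of compound.
Compound 2, `O=C(O)c1ccccc1-c1ccc(CCc2ncc(CCC3CCCCC3)[nH]2)cc1`, gives 33 nM.
Compound 3, `CC(C)CCc1cnc(CCc2ccc(-c3ccccc3C(=O)O)cc2)[nH]1`, gives 10 nM.

All three share the same core and differ only in the saturated group carried on an aromatic carbon. Compound 3 has the lowest number of the three, yet its gap to compound 1 lies within the scatter, so the two cannot be ranked against each other; compound 2 does stand apart, as the step of a 3.3-fold lower number from compound 2 to compound 3 (0.52 log units; beyond the scatter) shows. Compound 4, `O=C(O)c1ccccc1-c1ccc(CCc2ncc(CC3CCCCCC3)[nH]2)cc1`, has not yet been measured. It differs from compound 3 by cycloheptyl in place of isobutyl on a saturated chain carbon bound to an aromatic carbon. Among the measured compounds shown here, two measured steps bear on this change. Replacing a ring by a branched chain on the aromatic carbon changed little: a 1.5-fold lower number from compound 1 to compound 3 (0.17 log units; within the scatter). Moving a ring two bonds along a chain gave a higher number: a 2.2-fold higher number from compound 1 to compound 2 (0.35 log units; beyond the scatter). In compound 4 the ring sits on a saturated chain carbon bound to an aromatic carbon, neither directly on the aromatic carbon as in compound 1 nor two bonds along the chain as in compound 2, so only a small rise in the number, if any, is expected. Compound 4 is therefore estimated at 18 nM, within a range of 7 nM to 45 nM, which is expected to mean a 1.8-fold higher number from compound 3 to compound 4 (0.26 log units; within the scatter).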

Compound 4, half-maximal effective concentration: 5.7 nM
Estimate against measurement, compound 4: 3.2-fold (0.50 log units) above; the whole stated range lies above it.
By their numbers in this assay, from the lowest: compounds 4, 3 and 1 (each within the scatter of the next, the first and the last beyond it); then compound 2.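

Cycloheptyl on a saturated chain carbon bound to an aromatic carbon cannot be told apart from isobutyl at that place, since a 1.8-fold lower number from compound 3 to compound 4 (0.24 log units; within the scatter) stays within the scatter. The larger ring is therefore accepted here: with 7 carbon atoms in place of 4, and with a ring in place of an open branched group, compound 4 gives no sign of a loss. Compound 2 had hinted that a chain between the ring and the aromatic carbon raises the number, but compound 4 goes against any such general rule, with a 2.6-fold lower number from compound 1 to compound 4 (0.41 log units; beyond the scatter) and a 5.8-fold lower number from compound 2 to compound 4 (0.76 log units; beyond the scatter), both beyond the scatter.

On these data alone, compound 2 and compound 4 differ in both ring size and chain length, so the share of each remains unknown, and a cyclohexylmethyl group on the aromatic carbon, or a ring holding an amine at this place, would test this further. No measurement among the compounds shown explains why these groups give different numbers.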